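Swapping a carbamoyl for an ester chain on the core

The source may hold more compounds than are shown below. What is called first, only, known or untested is meant among the compounds shown, and "the series" means these compounds.

Three close relatives of one sugar-like core have been tested in a functional assay on HEL cells (Homo sapiens); on this read-out higher numbers stand for lower toxicity in this test and lower numbers for higher toxicity in this test. Compound 1 `Cc1cn([C@@H]2O[C@H](CO[Si](C)(C)C(C)(C)C)[C@@]3(OS(=O)(=O)C=C3NC(N)=O)[C@H]2O[Si](C)(C)C(C)(C)C)c(=O)n(C)c1=O` gives 11000 nM and stands as the lowest of the two numbers recorded, so it is the most toxic of the compounds that returned a number. Compound 2 `COC(=O)CC(=O)NC1=CS(=O)(=O)O[C@@]12[C@@H](CO[Si](C)(C)C(C)(C)C)O[C@@H](n1cc(C)c(=O)n(C)c1=O)[C@@H]2O[Si](C)(C)C(C)(C)C` gives 29000 nM, a change described by a 2.6-fold higher number from compound 1 to compound 2 (0.42 log units; beyond the scatter). Compound 3 `Cc1cn([C@@H]2O[C@H](CO[Si](C)(C)C(C)(C)C)[C@@]3(OS(=O)(=O)C=C3NCC(=O)OCc3ccccc3)[C@H]2O[Si](C)(C)C(C)(C)C)c(=O)n(C)c1=O` reached only a limit of the assay, > 200000 nM, as noted in the limit of > 200000 nM in this assay, at which 1 of the 3 values shown sits.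

Compound 4 `COC(=O)CCNC1=CS(=O)(=O)O[C@@]12[C@@H](CO[Si](C)(C)C(C)(C)C)O[C@@H](n1cc(C)c(=O)n(C)c1=O)[C@@H]2O[Si](C)(C)C(C)(C)C` is not yet measured. It differs from compound 1 in one place: 2-(methoxycarbonyl)ethyl in place of carbamoyl on an amine nitrogen.

Among the measured compounds shown here, two measured steps bear on this. The change to compound 2 was small, a 2.6-fold higher number from compound 1 to compound 2 (0.42 log units; beyond the scatter), while replacing the carbamoyl with an ester-bearing chain was large, an at least 18-fold higher number from compound 1 to compound 3 (1.25 log units; beyond the scatter), and the intermediate comparison an at least 6.8-fold higher number from compound 2 to compound 3 (0.83 log units; beyond the scatter) points the same way. Compound 4 also carries an ester-bearing chain on the amine nitrogen in place of the carbamoyl, so a clear rise in the number, toward lower toxicity, is expected, though the chain differs from that of compound 3.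

Compound 4 is therefore estimated at 100000 nM, within a range of 30000 nM to 300000 nM, an expected step of a 9.1-fold higher number from compound 1 to compound 4 (0.96 log units; beyond the scatter).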

Compound 4, half-maximal cytotoxic concentration: 94000 nM
Compound 4: the middle estimate sits 1.1-fold (0.03 log units) above what was measured; the measured number falls inside the stated range.
By their numbers in this assay, from the lowest: compound 1; then compound 2; then compound 4. At a limit, above all of these: compound 3.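

In this assay, the ester chain on the amine nitrogen lifts the number without a benzyl group, as the step of an 8.5-fold higher number from compound 1 to compound 4 (0.93 log units; beyond the scatter) shows, and the step of a 3.2-fold higher number from compound 2 to compound 4 (0.51 log units; beyond the scatter) shows that a methyl ester alone does not settle the outcome, since the chains in these two compounds both end in one and differ in the ((methoxycarbonyl)methyl)carbonyl versus 2-(methoxycarbonyl)ethyl attachment. The chain in the third relative still gives the least toxic reading, seen in the step of an at least 2.1-fold lower number from compound 3 to compound 4 (0.32 log units; beyond the scatter), so the choice of chain on this nitrogen keeps mattering among the ester-bearing groups. The reading for compound 3 is a limit of the assay and not a number: the limit of > 200000 nM in this assay, at which 1 of the 4 values shown sits.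

Compound 3 and compound 4 differ in both chain length and ester type, so the shown data cannot say which of the two accounts for their gap; a (methoxycarbonyl)methyl or a 2-(benzyloxycarbonyl)ethyl chain on the same nitrogen would separate them. Also open, on these data alone, is how a carboxylic acid in place of the methyl ester, or a longer chain, would read in this assay.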